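Arylpiperazine exchange on the hexanamide series

The source may hold more compounds than are shown below. What is called first, only, known or untested is meant among the compounds shown, and "the series" means these compounds.

Of the compounds shown here, two carry numbers so far. Compound 1 `COc1ccc2c(c1)CCCC2NC(=O)CCCN1CCN(c2ccccc2OC)CC1` gives 186 nM in an assay on HEK293 cells for displacement of a labelled ligand from 5-hydroxytryptamine receptor 7 (Rattus norvegicus); a higher number here means a weaker inhibitor, a lower number a stronger inhibitor. Compound 2 `O=C(CCCCCN1CCN(c2noc3ccccc23)CC1)NC1CCCc2ccccc21` gives 125 nM in this assay. Compound 2 holds the lowest of the two numbers, with compound 1 nearest; the gap between the two lies within the usual scatter, so no order between them can be read from this pair.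

Compound 3 `COc1ccc(OC)c(N2CCN(CCCCCC(=O)NC3CCCc4ccccc43)CC2)c1` differs from compound 2 in one place: a group of 10 heavy atoms (8 carbon, 2 oxygen; one six-membered aromatic ring of carbon only) in place of a group of 9 heavy atoms (7 carbon, 1 nitrogen, 1 oxygen; one five-membered aromatic ring with 2 hetero atoms, one six-membered aromatic ring of carbon only), on an amine nitrogen in a ring. Within the data shown here, no pair of measured compounds differs in a single place, so there is no measured step of this kind to lean on. What the numbers do show is that compound 1, built on the same pattern but not identical elsewhere, gives 186 nM, a number in the same range as compound 2. On that basis the step from compound 2 to compound 3 is expected to be small, with no clear direction, and the estimated 1.1-fold lower number from compound 2 to compound 3 (0.06 log units; within the scatter) stays within the scatter. Compound 3 is therefore expected to give 110 nM in this assay, with a range from 30 nM to 400 nM.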

Compound 3, inhibition constant: 70.3 nM
Beside the measured number, compound 3's estimate is 1.6-fold (0.19 log units) above it, within the range that was stated.
By their numbers in this assay, from the lowest: compounds 3, 2 and 1 (each within the scatter of the next, the first and the last beyond it).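

Among these compounds, compound 3 supplies the first measured single-place step at the amine nitrogen of the piperazine ring (a 1.8-fold lower number from compound 2 to compound 3 (0.25 log units; within the scatter)), and in this assay this exchange of the two-ring group for 2,5-dimethoxyphenyl cannot be told apart from the scatter. On this pair, the five-membered aromatic ring with its 2 hetero atoms is not needed to keep the number in this range on the hexanamide chain, since a single six-membered aromatic ring of carbon only, bearing two methoxy groups, serves equally well within the resolution of the measurement. No data on hand explain why the two groups read alike.

With a single step at this position, no trend can be drawn for it, and the compounds shown leave open how a plain phenyl, a pyridine ring or a 2,5-dichlorophenyl group on the same ring nitrogen would read in this assay on this chain. Also open, from the compounds shown here alone, is whether each of the two methoxy groups matters on its own, and whether the same exchange would give a similar step on a shorter chain.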